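Aryl Swap on the Shared Core: Expected Seizure Protection

The compounds below may be only part of what the source reports. "The series", "measured", "known", "first", "only" and "open" are said of these compounds alone.

Three compounds have been measured in a functional assay on the whole organism (strain Swiss) with Mus musculus as the target, in the maximal electroshock model, with a stated time of 0.5 h, at a dose of 100 mg/kg by the intraperitoneal route; a lower number here means a weaker effect, a higher number a stronger effect of the compound at the dose given:

Compound 1, `CC(C(=O)N1CCN(c2ccccc2F)CC1)N1C(=O)CCC1=O`: 0%
Compound 2, `CCC(C(=O)N1CCN(c2ccccc2F)CC1)N1C(=O)CCC1=O`: 0%
Compound 3, `CC(C(=O)N1CCN(c2ccccc2C(F)(F)F)CC1)N1C(=O)CCC1=O`: 25%

Compound 1 stands level with compound 2 at the digits printed, and the two together hold the lowest numbers of the three. The step of no change at the digits printed from compound 1 to compound 2 (within the scatter), a methyl in place of hydrogen on the saturated chain carbon, leaves the read-out where it was. The step of a number 25 percentage points higher from compound 1 to compound 3 (beyond the scatter), trifluoromethyl in place of fluoro on an aromatic carbon, is the only movement seen so far, and it is modest.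

Compound 4, `Cc1cccc(N2CCN(C(=O)C(C)N3C(=O)CCC3=O)CC2)c1`, differs from compound 1 in this way: 3-methylphenyl in place of 2-fluorophenyl on an amine nitrogen in a ring. Among the compounds with values here, of the two measured steps, only the one from compound 1 to compound 3 touches the aromatic ring on the amine nitrogen, and it exchanges one group for another rather than moving to 3-methylphenyl; the step from compound 1 to compound 2 concerns the chain and says nothing about the aryl. A small rise, or no change beyond the scatter, is therefore expected for compound 4, that is, an expected step of a number 10 percentage points higher from compound 1 to compound 4 (within the scatter).

The estimate for compound 4 in this assay is 10%, expected to lie between 0% and 35%.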

Compound 4, a percentage reported as activity, at one dose (the size of the read-out at that dose, not a potency): 0%
The estimate for compound 4 lay 10 percentage points above the measured number; the measured number falls inside the stated range.
By their numbers in this assay, from the lowest: compounds 1, 2 and 4 (each within the scatter of the next); then compound 3.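

In this assay, the exchange of 3-methylphenyl for 2-fluorophenyl on the amine nitrogen gives no change at the digits printed from compound 1 to compound 4 (within the scatter), so a change of the aryl group at this position does not always move the read-out, whereas the trifluoromethyl exchange gave a number 25 percentage points higher from compound 1 to compound 3 (beyond the scatter). With compound 1 already at 0%, this step could register a rise but not a fall, so it shows only that 3-methylphenyl brings no gain beyond the scatter at this dose and cannot show any loss relative to 2-fluorophenyl. No measurement here bears on why the aryl exchange left the read-out unmoved.

The step from 2-fluorophenyl to 3-methylphenyl changes both the substituent and its printed ring position, so the compounds shown leave the two contributions unseparated; 2-methylphenyl and 3-fluorophenyl would each change only one of them. As far as these compounds go, it also remains open whether unsubstituted phenyl or 3-trifluoromethylphenyl on the shared core would stay level with compound 1 or rise towards compound 3.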